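The source may hold more compounds than are shown below. What is called first, only, known or untested is meant among the compounds shown, and "the series" means these compounds.

- compound 1 `COc1cc(C(=O)Nc2ccc(C(=O)/C=C/c3nc(C)c(C)nc3C)cc2)cc(OC)c1OC`: 7350 nM
- compound 2 `Cc1nc(C)c(/C=C/C(=O)c2ccc(NC(=O)c3ccccc3F)cc2)nc1C`: 7390 nM
- compound 3 `COc1cccc(OC)c1C(=O)Nc1ccc(C(=O)/C=C/c2nc(C)c(C)nc2C)cc1`: 8470 nM

In a functional assay on A549 cells (Homo sapiens) for antiproliferative activity, read by CCK-8 assay, with a stated time of 72 h (on this read-out lower numbers stand for stronger inhibition and higher numbers for weaker inhibition), compound 3 gives 8470 nM, which lies within the scatter of the values for compound 1 and compound 2. The next compound, compound 4 `Cc1nc(C)c(/C=C/C(=O)c2ccc(NC(=O)c3ccccc3)cc2)nc1C`, has phenyl in place of 2,6-dimethoxyphenyl on a carbonyl carbon.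

One measured step changes the group at this same place: a 1.1-fold higher number from compound 2 to compound 3 (0.06 log units; within the scatter). Compound 1, with its own group on that carbonyl carbon, gives 7350 nM, and so also shows no separation from compound 3. Among the measured compounds shown here, no measurement yet shows the plain phenyl group, so this evidence is indirect and rests on only three compounds. Given the small size of a 1.1-fold higher number from compound 2 to compound 3 (0.06 log units; within the scatter), no change beyond the scatter is expected in this assay, and no direction can be argued with confidence. The expected step is a 1.1-fold lower number from compound 3 to compound 4 (0.05 log units; within the scatter). For compound 4, the estimated value is 7500 nM, with an expected range from 4000 nM to 14000 nM.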

Compound 4, half-maximal inhibitory concentration: 7270 nM
Beside the measured number, compound 4's estimate is 1.0-fold (0.01 log units) above it, and the stated range covers the measured number.
By their numbers in this assay, from the lowest: compounds 4, 1, 2 and 3 (each within the scatter of the next).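

In this assay, among the compounds shown here, the plain phenyl group gives the first reading for an unsubstituted ring on this carbonyl carbon, and it does not separate from 2,6-dimethoxyphenyl, with a 1.2-fold lower number from compound 3 to compound 4 (0.07 log units; within the scatter). Hydrogen in place of fluoro on an aromatic carbon likewise leaves the number within the scatter, with a 1.0-fold lower number from compound 2 to compound 4 (0.01 log units; within the scatter), so neither substituted ring in these two steps shows a measurable difference from phenyl at this position. Nothing available explains why these changes leave the number within the scatter.

Every group shown on this carbonyl carbon is a six-membered aromatic ring of carbon only, so these compounds leave open whether a pyridine ring, a saturated cyclohexyl ring or a short alkyl chain would give a number beyond the scatter. They also leave open whether an amine or a carboxylic acid on the phenyl ring would do so.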